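Dithiocarbamate amine variation on the shared core

The source may hold more compounds than are shown below. What is called first, only, known or untested is meant among the compounds shown, and "the series" means these compounds.

Compound 1 `CCN(Cc1ccncc1)C(=S)SCc1ccc(C(=O)Nc2ccccc2N)cc1` gives 85.2% in a functional assay on MGC-803 cells (Homo sapiens) for antiproliferative activity, read by CCK-8 assay, with a stated time of 72 h, tested at 8 uM (a lower number here means a weaker effect, a higher number a stronger effect of the compound at the concentration tested), the highest of the three numbers recorded. Compound 3 `Nc1ccccc1NC(=O)c1ccc(CSC(=S)N2CCc3cc(Cl)ccc32)cc1` gives 82.2%, and compound 2 `Nc1ccccc1NC(=O)c1ccc(CSC(=S)N2CCN(c3ccc(F)cc3)CC2)cc1` gives 48.7%; the values of compound 1 and compound 2 lie far apart, beyond the scatter.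

Compound 4 `CN1CCN(C(=S)SCc2ccc(C(=O)Nc3ccccc3N)cc2)CC1` has not been measured. It differs from compound 1 by 4-methylpiperazin-1-yl in place of ethyl((pyridin-4-yl)methyl)amino on a thiocarbonyl carbon.

Among the measured compounds shown here, one measured step bears on this change: a number 3 percentage points lower from compound 1 to compound 3 (within the scatter), where one amine on the thiocarbonyl carbon was exchanged for another without effect beyond the scatter. The values of compound 2 and compound 1 show, however, that an amine exchange at this position can also go with a much lower number. Compound 4 carries a piperazine like compound 2, but without the aryl group, so the expected step is a decrease, less sure in size than either comparison alone; the estimated step is a number 20.2 percentage points lower from compound 1 to compound 4 (beyond the scatter).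

For compound 4 the estimate in this assay is 65%, with a range from 40% to 88%.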

Compound 4, a percentage reported as inhibition, at one concentration (the size of the read-out at that concentration, not a potency): 84.4%
Compound 4: the middle estimate sits 19.4 percentage points below what was measured, within the range that was stated.
By their numbers in this assay, from the lowest: compound 2; then compounds 3, 4 and 1 (each within the scatter of the next).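

The 4-methylpiperazin-1-yl group on the thiocarbonyl carbon does not go with a lower number in this assay: the result is a number 0.8 percentage points lower from compound 1 to compound 4 (within the scatter) and a number 2.2 percentage points higher from compound 3 to compound 4 (within the scatter) so a piperazine ring at this position is compatible with the level of compound 1. The low number of compound 2 therefore goes with what sits on the amine nitrogen in the ring, not with the ring alone, as a number 35.7 percentage points higher from compound 2 to compound 4 (beyond the scatter) shows for methyl in place of 4-fluorophenyl. No measurement on hand accounts for this large step.

From the compounds shown here alone, whether the loss is specific to 4-fluorophenyl remains open, and a hydrogen, an acetyl or a benzyl on that same nitrogen would test it. The single test concentration also leaves any ranking among compounds 1, 3 and 4 undecided.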